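Benzyl swapped for pentyl on the alkyne arm

A few compounds are considered here, and "the series" means these few. Any claim that something is new, unique, unknown or untested is made for them only; others in the source may bear on it.

Measured so far in a functional assay on MCF7 cells (Homo sapiens) for antiproliferative activity, read by MTT assay, with a stated time of 72 h; on this read-out higher numbers stand for weaker inhibition and lower numbers for stronger inhibition:
Compound 1 `O=c1[nH]c(=O)n(CCC(CO)CO)cc1-c1ccco1` gives < 10 nM, a limit of the assay.
Compound 2 `O=c1[nH]c(=O)n(CCC(CO)CO)cc1-c1cccs1` gives 6000 nM.
Compound 3 `O=c1[nH]c(=O)n(CCC(CO)CO)cc1C#CCc1ccccc1` gives > 100000 nM, again a limit of the assay.

Only one pair of these compounds differs in a single place, and that step is an at least 600-fold higher number from compound 1 to compound 2 (2.77 log units; beyond the scatter); it concerns the five-membered aryl group on the aromatic carbon of the shared core. Compound 3 carries instead a benzyl group on a triple-bonded carbon, and it stands at the upper limit of this assay (the limit of > 100000 nM in this assay, at which 1 of the 3 values shown sits), so only a bound is known for it, whereas compound 1 sits at the lower limit (the limit of < 10 nM in this assay, at which 1 of the 3 values shown sits).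

Compound 4 `CCCCCC#Cc1cn(CCC(CO)CO)c(=O)[nH]c1=O` differs from compound 3 by butyl in place of phenyl on a saturated chain carbon bound to a triple-bonded carbon. Among the measured compounds shown here, no measured step touches this part of the molecule, since the single measured step involves the aryl group on the core, so it gives no direct guide to the size or direction of the change on the alkyne chain. Compound 3 sits at a limit in this assay, and compound 4 keeps the same core, the same diol chain and the same alkyne linker.

Compound 4 is therefore expected to remain in the same weak region, with an estimated 100000 nM, between 20000 nM and 400000 nM. For compound 4 this means an expected step of a number no higher from compound 3 to compound 4 (the limit leaves the size open), with a real chance that this assay once more reports only a limit.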

Compound 4, half-maximal inhibitory concentration: 37800 nM
The estimate for compound 4 lay 2.6-fold (0.42 log units) above the measured number; the measured number falls inside the stated range.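

In this assay, the alkyne arm now gives its first readable change: butyl in place of phenyl on a saturated chain carbon bound to a triple-bonded carbon gives an at least 2.6-fold lower number from compound 3 to compound 4 (0.42 log units; beyond the scatter), and this is only a bound, since compound 3 stands at a limit: the limit of > 100000 nM in this assay, at which 1 of the 4 values shown sits. The change shows that this arm can shift the number, yet the pentyl-bearing alkyne still does not reach the aryl compounds, with hept-1-yn-1-yl on the aromatic carbon giving a 6.3-fold higher number from compound 2 to compound 4 (0.80 log units; beyond the scatter) and, in place of furan-2-yl, an at least 3700-fold higher number from compound 1 to compound 4 (3.57 log units; beyond the scatter). That last step is also only a bound, as compound 1 is a limit of the assay: the limit of < 10 nM in this assay, at which 1 of the 4 values shown sits.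

The compounds shown leave open whether a shorter or longer chain on the alkyne, or a terminal hydroxyl or amine on it, would lower the number further than pentyl does. They also leave open how far the full size of the step from benzyl to pentyl reaches, and whether another ring on the aromatic carbon, such as pyridine, or a change in the diol chain would come near furan-2-yl.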